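Dimethylamino for trifluoromethyl: an estimate without a starting value

The source may report more compounds than this note shows. Statements on the series, on what has been measured and on what is new or still open speak of the compounds shown alone.

In a functional assay on A-375 cells (Homo sapiens) for inhibition, read by MTT assay, with a stated time of 4 days (a lower number here means a stronger inhibitor, a higher number a weaker inhibitor), compound 1 `CN1C[C@@H]2C[C@H]1CN2c1ccc(-c2ccnc3c(-c4cccc5[nH]ncc45)c(-c4ccncc4)nn23)cc1` gives 202 nM and compound 2 `Cc1cc(N2C[C@@H]3C[C@H]2CN3C)ccc1-c1ccnc2c(-c3cccc4[nH]ncc34)c(-c3ccncc3)nn12` gives 137 nM. Compound 3 `CN1C[C@@H]2C[C@H]1CN2c1ccc(-c2ccnc3c(-c4cccc5[nH]ncc45)c(-c4ccncc4)nn23)c(C(F)(F)F)c1` offers no starting point, as its entry reads "not determined" (no result reported). Compound 4 `CN(C)c1cc(N2C[C@@H]3C[C@H]2CN3C)ccc1-c1ccnc2c(-c3cccc4[nH]ncc34)c(-c3ccncc3)nn12` carries dimethylamino in place of trifluoromethyl on an aromatic carbon, ortho to a large group: dimethylamino in place of trifluoromethyl on an aromatic carbon. Within the data shown here, the one measured step, a 1.5-fold lower number from compound 1 to compound 2 (0.17 log units; within the scatter), is methyl in place of hydrogen on an aromatic carbon, and it bears only indirectly. Among the measured compounds shown here, with no number for compound 3, no step can be sized from it. Compound 4 is therefore expected to lie near compound 1 and compound 2, with no shift beyond the scatter. For compound 4 the estimated value is 170 nM, with an expected range of 70 nM to 420 nM.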

Compound 4, half-maximal inhibitory concentration: 1850 nM
Compound 4: middle estimate off by 11-fold (1.04 log units), on the low side; measured number above the stated range.
By their numbers in this assay, from the lowest: compounds 2 and 1 (each within the scatter of the next); then compound 4.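

In this assay, the position ortho to a large group proves sensitive to the group it carries: dimethylamino gives a 14-fold higher number from compound 2 to compound 4 (1.13 log units; beyond the scatter) and a 9.2-fold higher number from compound 1 to compound 4 (0.96 log units; beyond the scatter). The earlier change at this position, methyl for hydrogen, gave only a 1.5-fold lower number from compound 1 to compound 2 (0.17 log units; within the scatter), so that step did not show this sensitivity. Nothing available accounts for the rise with dimethylamino.

The step from compound 3 to compound 4 cannot be read, so trifluoromethyl offers no comparison. From the compounds shown here alone, whether a primary amine or a methoxy group here would stay with compound 1 or follow compound 4 remains open.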